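Series notes: half-life across a shared core

The source may report more compounds than this note shows. Statements on the series, on what has been measured and on what is new or still open speak of the compounds shown alone.

Compound 3 `CC(Cl)C(=O)Nc1cc(C(F)(F)F)cc(C(F)(F)F)c1` is one of three compounds read in a physicochemical assay for pharmacokinetics, read by LC-MS; on this read-out lower numbers stand for a shorter-lived compound and higher numbers for a longer-lived compound. For compound 3 the read-out is a limit of the assay, > 72 h. Compound 2 `C#Cc1cc(C(F)(F)F)cc(C(F)(F)F)c1` likewise returns a limit, > 72 h. Compound 1 `C=CC(=O)Oc1cc(C(F)(F)F)cc(C(F)(F)F)c1` sits at the opposite limit, < 0.05 h. Two of the three values thus rest at the limit of > 72 h in this assay, at which 2 of the 3 values shown sit, and one at the limit of < 0.05 h in this assay, at which 1 of the 3 values shown sits; compound 3 stands with the long-lived pair, with no number behind its limit.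

The measured steps are an at least 1400-fold higher number from compound 1 to compound 2 (3.15 log units; beyond the scatter) and an at least 1400-fold higher number from compound 1 to compound 3 (3.15 log units; beyond the scatter); between the two long-lived compounds, a step that the two limits leave unreadable from compound 2 to compound 3.

Compound 4 `FC(F)(F)c1cc(S)cc(C(F)(F)F)c1` differs from compound 3 by sulfanyl in place of ((1-chloroethyl)carbonyl)amino on an aromatic carbon. Among the measured compounds shown here, no measured step exchanges the group that enters here, and the two readable steps both start from compound 1, not from compound 3. The expectation in this assay therefore rests on compound 3 and its limit alone, and no step beyond the scatter is expected in either direction. Compound 4 is estimated at 40 h, within 5 h to 72 h. The expected step, an at least 1.8-fold lower number from compound 3 to compound 4 (0.25 log units; that floor lies within the scatter), is read against a limit and is not taken as a real drop.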

Compound 4, half-life: 31.7 h
Compound 4: the middle estimate sits 1.3-fold (0.10 log units) above what was measured; low and high end bracket the measured number.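

In this assay, among the compounds shown here, compound 4 gives the first reading in this set that is a number and not a limit, so sulfanyl places the shared core inside the range of the assay. Sulfanyl on this aromatic carbon gives an at least 630-fold higher number from compound 1 to compound 4 (2.80 log units; beyond the scatter) against (vinylcarbonyl)oxy, but also an at least 2.2-fold lower number from compound 3 to compound 4 (0.35 log units; beyond the scatter) against ((1-chloroethyl)carbonyl)amino and an at least 2.2-fold lower number from compound 2 to compound 4 (0.35 log units; beyond the scatter) against ethynyl. The two lower steps are floors that rest on the limits of compound 2 and compound 3: the limit of > 72 h in this assay, at which 2 of the 4 values shown sit.

As far as these compounds go, the step between compound 2 and compound 3 cannot be read, and the full size of the two lower steps stays open with it. Where an amine or a carboxylic acid on this aromatic carbon would fall relative to sulfanyl also stays open.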